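A few compounds are considered here, and "the series" means these few. Any claim that something is new, unique, unknown or untested is made for them only; others in the source may bear on it.

Measured compounds:
compound 1 `O=C(/C(=C\c1csc([N+](=O)[O-])c1)S(=O)(=O)c1ccc(Br)cc1)c1ccc(Br)cc1` — 1000 nM
compound 2 `CCOc1ccc(/C=C(\C(=O)c2ccc(Cl)cc2)S(=O)(=O)Cc2ccc(C)cc2)cc1OC` — 10000 nM
compound 3 `Cc1ccc(S/C(=C/c2ccc[nH]2)C(=O)c2ccc(Cl)cc2)cc1` — 10000 nM

All three values come from a functional assay on DU-145 cells (Homo sapiens) for inhibition, read by trypan blue exclusion, with a stated time of 96 h; on this read-out higher numbers stand for weaker inhibition of growth and lower numbers for stronger inhibition of growth. Compound 1 gives the lowest number of the three in this assay; compound 2 and compound 3 each stand a clear distance higher, and both of those gaps lie beyond the usual scatter, so compound 1 is the strongest inhibitor of growth among the measured set. Going by the values given here, no pair of measured compounds differs in only one place, so no single step can be read off from them; compound 2 and compound 3 differ from compound 1 in several parts at once, and their values show only that both inhibit growth more weakly than compound 1.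

Compound 4 `O=C(/C(=C\c1ccc(Cl)cc1)S(=O)(=O)c1ccc(Br)cc1)c1ccc(Br)cc1` has not been measured. Relative to compound 1 the change is: 4-chlorophenyl in place of 5-nitrothiophen-3-yl on a double-bonded chain carbon bound to a double-bonded chain carbon The rest of the core of compound 1 is kept. Among the compounds with values here, none of the measured compounds isolates this change, so it has to be judged without a direct precedent. The step of a 2.5-fold higher number from compound 1 to compound 4 (0.40 log units; beyond the scatter) is expected to be a modest rise in the number, close to the edge of the scatter. For compound 4 the estimate in this assay is 2500 nM, with a range from 700 nM to 10000 nM.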

Compound 4, concentration for 50% growth inhibition: 50000 nM
Beside the measured number, compound 4's estimate is 20-fold (1.30 log units) below it; measured number outside the range, above it.
By their numbers in this assay, from the lowest: compound 1; then compounds 2 and 3 (each within the scatter of the next); then compound 4.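

In this assay, the place on a double-bonded chain carbon bound to a double-bonded chain carbon proves highly sensitive: with the rest of the core of compound 1 kept, 4-chlorophenyl in place of 5-nitrothiophen-3-yl gives a 50-fold higher number from compound 1 to compound 4 (1.70 log units; beyond the scatter), a large loss of growth inhibition. Going by these compounds alone, this is the only step confined to one place, whereas the earlier compounds differ in several parts at once and could not tie any part of the gap to this position. The change alters the ring size, the hetero atom and the count of hydrogen-bond acceptors together, and nothing available shows which of these accounts for the step.

Within the data shown here, the single step cannot separate the nitro group from the thiophene ring, so an unsubstituted thiophen-3-yl and a nitrophenyl at this place are the open comparisons. From the compounds shown here alone, whether the sensitivity extends to other groups here, such as an aminophenyl or a carboxylic acid on the ring, and whether it holds with other groups on the sulfonyl and carbonyl sides, also remains open.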